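Working notes: benzyl swap on the phenyl-bearing series

The compounds below may be only part of what the source reports. "The series", "measured", "known", "first", "only" and "open" are said of these compounds alone.

In a functional assay on HeLa cells (Homo sapiens) for antiproliferative activity, read by MTT assay, with a stated time of 48 h (on this read-out lower numbers stand for stronger inhibition and higher numbers for weaker inhibition), compound 1 (`Fc1ccccc1CSc1nnc(-c2cnccn2)o1`) gives 25300 nM. Compound 2 (`Clc1ccccc1CSc1nnc(-c2cnccn2)n1-c1ccccc1`) gives > 50000 nM, which is only a limit of this assay, so it sits at the limit of > 50000 nM in this assay, at which 1 of the 2 values shown sits. Compound 3 (`Brc1ccc(CSc2nnc(-c3cnccn3)n2-c2ccccc2)cc1`) carries 4-bromophenyl in place of 2-chlorophenyl on a saturated chain carbon bound to a sulfur. Among the compounds with values here, no measured step covers this change. The expected size of the step is none beyond the scatter: an at least 1.2-fold lower number from compound 2 to compound 3 (0.09 log units; that floor lies within the scatter). Compound 3 is estimated at 40000 nM, with an expected range of 15000 nM to 80000 nM.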

Compound 3, half-maximal inhibitory concentration: 8630 nM
For compound 3 the middle estimate is 4.6-fold (0.67 log units) above the measured one, outside the stated range (below it).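

In this assay, this position on a saturated chain carbon bound to a sulfur proves responsive: 4-bromophenyl in place of 2-chlorophenyl gives an at least 5.7-fold lower number from compound 2 to compound 3 (0.76 log units; beyond the scatter). Within the data shown here, this is the first readable single-place step, since compound 1 and compound 2 differ in more than one place. Its size stands only as a floor: the limit of > 50000 nM in this assay, at which 1 of the 3 values shown sits.

The halogen and its place on the phenyl change together, so the step cannot be assigned to either alone. On these data alone, whether an amine or a carboxylic acid on the phenyl, or a longer chain, would keep this gain remains open.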